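Ring-nitrogen alkyl: propyl to isopropyl in the series

The source may hold more compounds than are shown below. What is called first, only, known or untested is meant among the compounds shown, and "the series" means these compounds.

Working notes. Compound 1 `Cn1ncnc1-c1ccccc1NCC1=NCCN1` is the reference point of the pair measured so far; in an in vitro functional assay on cells (Fibroblast) for agonist activity at Alpha-1A adrenergic receptor (Homo sapiens) (a lower number here means that less compound is needed, a higher number that more compound is needed for the effect), compound 1 gives 2 nM. Compound 2 `CCCn1ncnc1-c1ccccc1NCC1=NCCN1` differs only in the group on the ring nitrogen, and in this assay compound 2 gives 12.6 nM. For the measured compounds named here, the single step measured, a 6.3-fold higher number from compound 1 to compound 2 (0.80 log units; beyond the scatter), is the only one in hand. Going by the values given here, compound 2 therefore holds the higher of the two numbers, with compound 1 as its only neighbour at the lower one.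

Compound 3 `CC(C)n1ncnc1-c1ccccc1NCC1=NCCN1` is the next point: isopropyl in place of propyl on an aromatic nitrogen. Among the compounds with values here, the two structures hold the same atoms joined differently, so no measured step maps onto this change directly. The step from compound 1 to compound 2 bears on it only loosely, since it shows that a larger alkyl on that nitrogen than methyl raised the number, and compound 3 stays at the propyl size. For compound 3 a step of a 1.2-fold higher number from compound 2 to compound 3 (0.08 log units; within the scatter) is expected in this assay, most likely within the scatter. The estimate for compound 3 in this assay is 15 nM, with a range from 5 nM to 50 nM.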

Compound 3, half-maximal effective concentration: 6.31 nM
Compound 3: the middle estimate sits 2.4-fold (0.38 log units) above what was measured; the range from low to high includes it.
By their numbers in this assay, from the lowest: compound 1; then compounds 3 and 2 (each within the scatter of the next).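

On the aromatic nitrogen, in this assay, isopropyl in place of propyl gives a 2.0-fold lower number from compound 2 to compound 3 (0.30 log units; within the scatter) and so the two arrangements of the same atoms are not separated by this read-out. Isopropyl in place of methyl gives a 3.2-fold higher number from compound 1 to compound 3 (0.50 log units; beyond the scatter) and this shows that the higher number seen with propyl is not confined to the unbranched chain: both groups tested here stand apart from methyl, and neither stands apart from the other. Nothing available explains the result.

The compounds shown leave open how the number moves between methyl and the larger groups, as ethyl would sit in that interval, and whether it keeps rising with a longer chain such as butyl or with a more heavily branched group such as tert-butyl. Also open, on these data alone, is whether cyclopropyl, with its ring, or a chain carrying a hydroxyl group would behave like propyl and isopropyl on this nitrogen, and whether a free hydrogen there would fall nearer to methyl.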